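The source may report more compounds than this note shows. Statements on the series, on what has been measured and on what is new or still open speak of the compounds shown alone.

Compound 2 `Nc1scc(CN2CCN(c3ccc(Cl)cc3Cl)CC2)c1C(=O)c1ccc(Cl)cc1` carries a 2,4-dichlorophenyl on an amine nitrogen in a ring. In a functional assay on CHO cells with adenosine receptor A1 (Homo sapiens) as the target, read by cAMP accumulation and immunoassay, with a stated time of 6 min, tested at 1 uM (a lower number here means a stronger effect, a higher number a weaker effect of the compound at the concentration tested), compound 2 gives -54%. Of the three numbers in hand it stands second highest: compound 3 `Nc1scc(CN2CCN(c3cc(Cl)cc(Cl)c3)CC2)c1C(=O)c1ccc(Cl)cc1` lies nearest, with -69%, the step being a number 15 percentage points lower from compound 2 to compound 3 (beyond the scatter); compound 1 `CC(C)N1CCN(Cc2csc(N)c2C(=O)c2ccc(Cl)cc2)CC1` lies furthest, with 7.3%, the step being a number 61.3 percentage points lower from compound 1 to compound 2 (beyond the scatter).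

Compound 4 `COc1ccc(N2CCN(Cc3csc(N)c3C(=O)c3ccc(Cl)cc3)CC2)cc1` is not yet measured. Its change from compound 2: 4-methoxyphenyl in place of 2,4-dichlorophenyl on an amine nitrogen in a ring. For the measured compounds named here, three measured steps touch this same position. The two that replace isopropyl with a dichlorophenyl, a number 61.3 percentage points lower from compound 1 to compound 2 (beyond the scatter) and a number 76.3 percentage points lower from compound 1 to compound 3 (beyond the scatter), were large; the one that moves between two dichlorophenyls, a number 15 percentage points lower from compound 2 to compound 3 (beyond the scatter), was modest. Going by the values given here, compound 4 keeps a six-membered aromatic ring of carbon at this position, so compounds 2 and 3 are taken as the better guide than compound 1; no measured step replaces a dichlorophenyl with 4-methoxyphenyl here, so the direction is uncertain. A step of about a number 24 percentage points higher from compound 2 to compound 4 (beyond the scatter) is expected, toward a higher number or none beyond the scatter. For compound 4 the expected value in this assay is -30%, with a range of -70% to 10%.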

Compound 4, a percentage reported as activity, at one concentration (the size of the read-out at that concentration, not a potency): -15%
Compound 4: the middle estimate sits 15 percentage points below what was measured; the range from low to high includes it.
By their numbers in this assay, from the lowest: compound 3; then compound 2; then compound 4; then compound 1.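

In this assay the aromatic groups at this position no longer behave as one class, since a number 39 percentage points higher from compound 2 to compound 4 (beyond the scatter) and a number 54 percentage points higher from compound 3 to compound 4 (beyond the scatter) are both large steps. Keeping a six-membered aromatic ring of carbon on the amine nitrogen is therefore not enough to keep compound 4 level with the two dichlorophenyl compounds. The gain over isopropyl also shrinks with 4-methoxyphenyl, as a number 22.3 percentage points lower from compound 1 to compound 4 (beyond the scatter) is only a modest step, so the large steps seen earlier hold for the dichlorophenyls and not for every aromatic group here.

No measurement in hand gives a reason for these differences.

Still open, as far as these compounds go, is whether losing the two chlorines or gaining the methoxy drives the shift, which an unsubstituted phenyl or a 4-chlorophenyl at this place could separate.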